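Swapping the 1-carboxyethyl group of compound 3

The source may hold more compounds than are shown below. What is called first, only, known or untested is meant among the compounds shown, and "the series" means these compounds.

In a functional assay on MCF7 cells (Homo sapiens) for antiproliferative activity, read by MTT assay, with a stated time of 48 h (a lower number here means a stronger inhibitor, a higher number a weaker inhibitor), compound 1 (`CCn1c(C(=O)NCCN(C)C)ccc1C(CC)(CC)c1ccc(OCCC(O)(CC)CC)c(C)c1`) gives 430 nM and compound 2 (`CCn1c(C(=O)NC(CC(=O)O)C(=O)OC)ccc1C(CC)(CC)c1ccc(OCCC(O)(CC)CC)c(C)c1`) gives 10200 nM while compound 3 (`CCn1c(C(=O)NC(C)C(=O)O)ccc1C(CC)(CC)c1ccc(OCCC(O)(CC)CC)c(C)c1`) gives 19700 nM at the high end of the series. One gap lies within the scatter (a 1.9-fold higher number from compound 2 to compound 3 (0.29 log units; within the scatter)) and the other is large (a 46-fold higher number from compound 1 to compound 3 (1.66 log units; beyond the scatter)).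

Compound 4 (`CCC(C)C(CO)NC(=O)c1ccc(C(CC)(CC)c2ccc(OCCC(O)(CC)CC)c(C)c2)n1CC`) carries 1-(hydroxymethyl)-2-methylbutyl in place of 1-carboxyethyl on an amide-type nitrogen. Among the compounds with values here, no measured step makes this exchange. The nearest guides are the large steps away from compound 1 (a 24-fold higher number from compound 1 to compound 2 (1.38 log units; beyond the scatter)) and (a 46-fold higher number from compound 1 to compound 3 (1.66 log units; beyond the scatter)). Part of that rise may be recovered once 1-carboxyethyl leaves, so a moderate step to a lower number is expected in this assay (a 7.9-fold lower number from compound 3 to compound 4 (0.90 log units; beyond the scatter)). Compound 4 is estimated at 2500 nM with a range of 500 nM to 12000 nM in this measurement.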

Compound 4, half-maximal inhibitory concentration: 29100 nM
Compound 4: the middle estimate sits 12-fold (1.07 log units) below what was measured; measured number outside the range, above it.
By their numbers in this assay, from the lowest: compound 1; then compounds 2, 3 and 4 (each within the scatter of the next, the first and the last beyond it).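

In this assay, 1-(hydroxymethyl)-2-methylbutyl, which has no carboxylic acid, stays within the scatter of 1-carboxyethyl on the amide-type nitrogen (a 1.5-fold higher number from compound 3 to compound 4 (0.17 log units; within the scatter)), so losing that acid alone brings no recovery here. The modest gap to the group on compound 2 (a 2.9-fold higher number from compound 2 to compound 4 (0.46 log units; beyond the scatter)) and the large gap to 2-(dimethylamino)ethyl (a 68-fold higher number from compound 1 to compound 4 (1.83 log units; beyond the scatter)) leave compound 1 alone at the low end. Nothing available here explains these steps.

As far as these compounds go, whether the low number of compound 1 depends on its tertiary amine or on the chain carrying it remains open. A primary amine or a longer chain ending in dimethylamino could separate the two.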